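Aryl amine variants on the shared core

The source may report more compounds than this note shows. Statements on the series, on what has been measured and on what is new or still open speak of the compounds shown alone.

Compound 1 `CCCNc1cccc(NC(=O)c2ccc(OCCC)cc2)n1` gives 15400 nM in an in vitro assay on HEK-tsA201 cells for antagonist activity at Neuronal acetylcholine receptor; alpha4/beta2 (Homo sapiens), read by fluorescence and calcium flux; on this read-out higher numbers stand for weaker inhibition and lower numbers for stronger inhibition. Compound 2 `CCCCCNc1cccc(NC(=O)c2ccc(OCCC)cc2)n1` sits at a limit of this assay, > 100000 nM. Compound 3 `CCCOc1ccc(C(=O)Nc2cccc(Nc3cccc(F)c3)n2)cc1` likewise sits at a limit, > 100000 nM. The step of an at least 6.4-fold higher number from compound 1 to compound 3 (0.81 log units; beyond the scatter) shows that 3-fluorophenyl in place of propyl on a nitrogen on an aromatic ring weakens inhibition, and an at least 6.4-fold higher number from compound 1 to compound 2 (0.81 log units; beyond the scatter) shows the same for the longer chain. The step that the two limits leave unreadable from compound 2 to compound 3 cannot be read because both values sit at the limit of > 100000 nM in this assay, at which 2 of the 3 values shown sit. Among the measured compounds shown here, compound 3 thus stands at the limit, alongside compound 2, with compound 1 the only member that returns a number.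

Compound 4 `CCCOc1ccc(C(=O)Nc2cccc(Nc3ccc(Cl)cc3)n2)cc1` differs from compound 3 by 4-chlorophenyl in place of 3-fluorophenyl on a nitrogen on an aromatic ring. For the measured compounds named here, no measured step alters a substituent on an aryl group at that nitrogen; the steps that bear on it, an at least 6.4-fold higher number from compound 1 to compound 3 (0.81 log units; beyond the scatter) and an at least 6.4-fold higher number from compound 1 to compound 2 (0.81 log units; beyond the scatter), show only that the limit is reached once an aryl or longer group sits there. Compound 4 is therefore expected to stay at or near that limit, and the step that the limit leaves unreadable from compound 3 to compound 4 is expected to be none beyond the scatter. Compound 4 is estimated at 150000 nM, with a range from 30000 nM to 600000 nM.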

Compound 4, half-maximal inhibitory concentration: > 100000 nM
Compound 4 gave a limit, no number; the forecaster's own chance of this, stated with the estimate: 75%; the middle value does not contradict the limit.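

With an at least 6.4-fold higher number from compound 1 to compound 4 (0.81 log units; beyond the scatter), a second aryl group, 4-chlorophenyl, joins 3-fluorophenyl in weakening inhibition relative to propyl on this nitrogen in this assay. Compound 4 gives a limit and no number, > 100000 nM. The steps among compound 2, compound 3 and compound 4 cannot be read, so the swap of 3-fluorophenyl for 4-chlorophenyl has no measurable size, because all three values sit at one limit: the limit of > 100000 nM in this assay, at which 3 of the 4 values shown sit.

As far as these compounds go, only compound 1 returns a number, so how ethyl, butyl or an unsubstituted amine on this nitrogen would read stays open. From the compounds shown here alone, whether unsubstituted phenyl or benzyl would return a number at all also stays open, and so does any separate contribution of the fluorine or the chlorine.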